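The source may hold more compounds than are shown below. What is called first, only, known or untested is meant among the compounds shown, and "the series" means these compounds.

In a functional assay on A549 cells (Homo sapiens) for cytotoxicity, read by WST assay, with a stated time of 24 h (on this read-out higher numbers stand for weaker inhibition and lower numbers for stronger inhibition), compound 1 `N#C/C(=C\c1c[nH]c2ccccc12)C(=O)c1c[nH]c2ccccc12` gives 16100 nM. Compound 2 `COc1ccc2c(C(=O)/C(C#N)=C/c3cn(Cc4ccc(Cl)cc4)c4ccccc34)c[nH]c2c1` reports only a limit, > 50000 nM. Compound 3 `COc1ccc(Cn2cc(/C=C(\C#N)C(=O)c3c[nH]c4cc(OC)ccc34)c3ccccc32)cc1` gives 37400 nM, the higher of the two actual numbers, and its gap to compound 1 lies beyond the scatter.

Compound 4 `COc1ccc(Cn2cc(/C=C(\C#N)C(=O)c3c[nH]c4ccccc34)c3ccccc32)cc1` is still unmeasured. It differs from compound 3 by hydrogen in place of methoxy on an aromatic carbon, reading 6-methoxy-1H-indol-3-yl to 1H-indol-3-yl.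

Going by the values given here, no measured step makes this exact change. Among the compounds with values here, the only single-place step, an at least 1.3-fold lower number from compound 2 to compound 3 (0.12 log units; that floor lies within the scatter), is methoxy in place of chloro on an aromatic carbon, and it leaves the 6-methoxy group untouched, so it gives no size for this change. Compound 1 also lacks that methoxy but differs in other ways too, so its 16100 nM offers only a weak hint towards a lower number.

The expected result is a small move, within the scatter: a 1.3-fold lower number from compound 3 to compound 4 (0.13 log units; within the scatter). Compound 4 is estimated at 28000 nM, with an expected range of 12000 nM to 60000 nM.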

Compound 4, half-maximal inhibitory concentration: > 50000 nM
Compound 4 gave a limit, no number; the forecaster's own chance of this, stated with the estimate: 20%; middle value at least 1.7-fold (0.25 log units) from the limit.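

Removing the methoxy from the indole ring in the presence of the 4-methoxybenzyl group gives an at least 1.3-fold higher number from compound 3 to compound 4 (0.12 log units; that floor lies within the scatter) in this assay, so this change brings no lower number, and its floor cannot be told apart from no change. Going by these compounds alone, the 4-methoxybenzyl group on the aromatic nitrogen now has a direct reading, with no methoxy on either compound: an at least 3.1-fold higher number from compound 1 to compound 4 (0.49 log units; beyond the scatter), a step beyond the scatter and the first single-place comparison to show a clear effect of that substituent. On these data alone, compound 4 gives a limit rather than a number, as does compound 2, so both steps are floors and their true sizes stay unknown: the limit of > 50000 nM in this assay, at which 2 of the 4 values shown sit.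

As far as these compounds go, how far compound 4 lies past its limit stays open. Also open, from the compounds shown here alone, is whether a methyl or an aminoethyl chain on that aromatic nitrogen would keep the number of compound 1, 16100 nM, or move it upward.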